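Aryl variation in a three-compound series, and compound 4

The source may report more compounds than this note shows. Statements on the series, on what has been measured and on what is new or still open speak of the compounds shown alone.

Measured compounds:
Compound 1, `Cc1cc(O)c(C(C)C)cc1-c1cc(-c2cccs2)c(C#N)c(=O)[nH]1`: 26%
Compound 2, `Cc1cc(O)c(C(C)C)cc1-c1cc(-c2ccco2)c(C#N)c(=O)[nH]1`: 26%
Compound 3, `Cc1cc(O)c(C(C)C)cc1-c1cc(-c2ccc(N(C)C)cc2)c(C#N)c(=O)[nH]1`: 30%

In a functional assay for inhibition, tested at 20 ug/mL (on this read-out lower numbers stand for a weaker effect and higher numbers for a stronger effect at the one concentration tested), compound 1 gives 26% and compound 2 gives 26%; the step of no change at the digits printed from compound 1 to compound 2 (within the scatter). Compound 3 gives 30%, the highest of the three numbers, yet its separation from the others is small: a number 4 percentage points higher from compound 1 to compound 3 (within the scatter) and a number 4 percentage points higher from compound 2 to compound 3 (within the scatter). All three numbers therefore sit in one band, and no ranking among the aryl groups can be read from them.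

Compound 4, `Cc1cc(O)c(C(C)C)cc1-c1cc(-c2ccccc2[N+](=O)[O-])c(C#N)c(=O)[nH]1`, is not yet measured. It differs from compound 3 in one place: 2-nitrophenyl in place of 4-(dimethylamino)phenyl on an aromatic carbon. The three measured steps all exchange the aryl group at this same position, and none of them moved the read-out beyond the scatter. On that basis the expected step from compound 3 to compound 4 is a number 2 percentage points lower from compound 3 to compound 4 (within the scatter), a change no larger than the scatter. Compound 4 is thus estimated at 28% in this assay, with a range of 15% to 42%.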

Compound 4, a percentage reported as inhibition, at one concentration (the size of the read-out at that concentration, not a potency): 20%
The estimate for compound 4 lay 8 percentage points above the measured number, and the stated range covers the measured number.
By their numbers in this assay, from the lowest: compounds 4, 1, 2 and 3 (each within the scatter of the next).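

In this assay, placing 2-nitrophenyl on the carbon opposite the ring nitrogen gives a number 10 percentage points lower from compound 3 to compound 4 (within the scatter), along with a number 6 percentage points lower from compound 2 to compound 4 (within the scatter) and a number 6 percentage points lower from compound 1 to compound 4 (within the scatter). The step from 4-(dimethylamino)phenyl is the largest yet seen at this position, but thiophen-2-yl, furan-2-yl, 4-(dimethylamino)phenyl and 2-nitrophenyl still sit in one band, and no ranking among them can be read. Nothing available on these compounds bears on why the numbers fall as they do.

Still open, going by these compounds, is whether a carboxylic acid or an aminomethyl group at this position, or a saturated group such as cyclohexyl in place of the aryl ring, would move the read-out beyond the scatter. On these data alone, whether the nitro group would give a different number as 4-nitrophenyl also remains open, and this assay shows the size of the effect at one concentration only.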